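The source may report more compounds than this note shows. Statements on the series, on what has been measured and on what is new or still open speak of the compounds shown alone.

Compound 1, with the structure `COc1cc(Oc2cccc(Nc3ccccc3)c2)cc(OC)c1CNCc1ccc(F)cc1`, and compound 2, with the structure `CNCc1c(OC)cc(Oc2cccc(Nc3ccccc3)c2)cc1OC`, share one core and differ only in what sits on a saturated chain carbon bound to an amine nitrogen. In a functional assay on HT-29 cells (Homo sapiens) for inhibition, read by MTT assay, with a stated time of 72 h (on this read-out lower numbers stand for stronger inhibition and higher numbers for weaker inhibition), compound 1 gives 2750 nM. In this assay compound 2 gives 7430 nM. Among the measured compounds shown here, the single measured step, a 2.7-fold higher number from compound 1 to compound 2 (0.43 log units; beyond the scatter), shows that removing the 4-fluorophenyl group weakened inhibition, so compound 2 stands at the higher, weaker end of the two numbers.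

Compound 3, with the structure `COc1cc(Oc2cccc(Nc3ccccc3)c2)cc(OC)c1CNCc1ccc(C)cc1`, differs from compound 2 by 4-methylphenyl in place of hydrogen on a saturated chain carbon bound to an amine nitrogen. This is the reverse of the measured step, with a 4-methylphenyl group instead of a 4-fluorophenyl group, so the expected change is a return toward the number of compound 1, estimated as a 2.8-fold lower number from compound 2 to compound 3 (0.44 log units; beyond the scatter). Compound 3 is therefore expected to give about 2700 nM in this assay, within a range from 1000 nM to 7500 nM.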

Compound 3, half-maximal inhibitory concentration: 3880 nM
For compound 3 the middle estimate is 1.4-fold (0.16 log units) below the measured one; the range from low to high includes it.
By their numbers in this assay, from the lowest: compounds 1, 3 and 2 (each within the scatter of the next, the first and the last beyond it).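

Replacing hydrogen with 4-methylphenyl on the saturated chain carbon bound to an amine nitrogen gives, in this assay, a 1.9-fold lower number from compound 2 to compound 3 (0.28 log units; within the scatter). This differs from the earlier replacement of the same hydrogen by 4-fluorophenyl, where the reverse step reads a 2.7-fold higher number from compound 1 to compound 2 (0.43 log units; beyond the scatter), so only compound 1 is clearly separated from compound 2. Methyl in place of fluoro on an aromatic carbon gives a 1.4-fold higher number from compound 1 to compound 3 (0.15 log units; within the scatter), which means that compound 1 and compound 3 cannot be told apart here.

Going by these compounds, how a chloro or methoxy group on that aromatic carbon, or a plain phenyl or longer alkyl chain at the same position, would read remains open. Nothing available here explains these numbers.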